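A few compounds are considered here, and "the series" means these few. Any claim that something is new, unique, unknown or untested is made for them only; others in the source may bear on it.

The study covers three measured compounds and one that awaits measurement. Compound 1 `Nc1nc(OCc2ccccc2)c2[nH]c(O)nc2n1` has a core of its own, and in an assay on isolated protein for inhibition of Myeloperoxidase (Homo sapiens), read by fluorescence, with stated times of 10 min, 30 s and 5 min (on this read-out lower numbers stand for stronger inhibition and higher numbers for weaker inhibition), compound 1 returns only a limit, > 13000 nM, not a number. Compound 2 `Nc1nc(OCc2ccccc2F)c2nn[nH]c2n1` carries a fluorine on its six-membered aromatic ring of carbon only, and in this assay compound 2 gives 78 nM. Compound 3 `Nc1nc(OCc2ccc(F)cc2)c2nn[nH]c2n1` also carries one fluorine on that ring; in this assay compound 3 gives 47 nM, a value that lies within the usual scatter of the value of compound 2, so the two cannot be told apart. Compound 4 `Nc1nc(OCc2ccc(C(F)(F)F)cc2)c2nn[nH]c2n1` differs from compound 3 in one place: trifluoromethyl in place of fluoro on an aromatic carbon. Among the measured compounds shown here, no measured pair in this set follows such a change, so its effect is open. The expected step of a 1.3-fold higher number from compound 3 to compound 4 (0.11 log units; within the scatter) stays within the scatter, with no set direction. For compound 4 the estimate in this assay is 60 nM, with a range from 15 nM to 250 nM.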

Compound 4, half-maximal inhibitory concentration: 140 nM
The estimate for compound 4 lay 2.3-fold (0.37 log units) below the measured number; measured number inside the range.
By their numbers in this assay, from the lowest: compounds 3, 2 and 4 (each within the scatter of the next, the first and the last beyond it). At a limit, above all of these: compound 1.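

In this assay, trifluoromethyl in place of fluoro on an aromatic carbon, para to a large group, gives a 3.0-fold higher number from compound 3 to compound 4 (0.47 log units; beyond the scatter). Among the compounds shown here, this is the first step in the set that differs in one place, and it shows that the position responds to the exchange, although only modestly, since compound 4 still returns a number in the same assay and not a limit. Nothing measured here accounts for the size or direction of this step.

On these data alone, whether other groups at this place, such as chloro, methoxy, a nitrile, an amine or a carboxylic acid, would lie nearer compound 3 or further from it stays open. Also open, as far as these compounds go, is whether trifluoromethyl in place of the fluoro of compound 2 would give a step of similar size.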